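The compounds below may be only part of what the source reports. "The series", "measured", "known", "first", "only" and "open" are said of these compounds alone.

Measured compounds:
Compound 1 `Cc1oc2c([C@H]3CCN(C)C[C@H]3O)c(O)cc(O)c2c(=O)c1C(O)c1ccc(Cl)cc1`: 15%
Compound 2 `Cc1oc2c([C@H]3CCN(C)C[C@H]3O)c(O)cc(O)c2c(=O)c1C(O)c1ccc(F)cc1`: 17%
Compound 3 `CN1CC[C@H](c2c(O)cc(O)c3c(=O)cc(/C=C/c4ccccc4F)oc23)[C@H](O)C1`: 60%

In a functional assay on MIA PaCa-2 cells (Homo sapiens) for inhibition, read by MTT assay, with a stated time of 48 h, tested at 10 uM (on this read-out lower numbers stand for less inhibition of growth and higher numbers for more inhibition of growth at the one concentration tested), compound 1 gives 15% and compound 2 gives 17%. These two share one core and differ only by chloro in place of fluoro on an aromatic carbon, where the place is para to a large group. That change makes a number 2 percentage points lower from compound 2 to compound 1 (within the scatter), so the two numbers cannot be told apart.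

Compound 3 stands on a different core, and the difference between the two cores is not broken down here; in this assay compound 3 gives 60%, which lies beyond the scatter above both compound 2 and compound 1.

Compound 4 `CN1CC[C@H](c2c(O)cc(O)c3c(=O)cc(/C=C/c4ccccc4Cl)oc23)[C@H](O)C1` is not yet measured. It differs from compound 3 by chloro in place of fluoro on an aromatic carbon, here at a place ortho to a large group. The place around the change is not the same as for the pair of compound 2 and compound 1. The change is thus the same kind of change rather than the same change. Going by the values given here, still, the only measured instance of this kind of change is a number 2 percentage points lower from compound 2 to compound 1 (within the scatter), a step inside the scatter, so the expected step is a number 2 percentage points lower from compound 3 to compound 4 (within the scatter), which rests on that earlier pair. For compound 4 the expected value in this assay is 58%, with a range from 44% to 72%.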

Compound 4, percent growth inhibition at one concentration: 59%
Estimate against measurement, compound 4: 1 percentage points below, within the range that was stated.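

Exchanging fluoro for chloro on the aromatic carbon of the 2-fluorophenyl group gives, in this assay, a number 1 percentage points lower from compound 3 to compound 4 (within the scatter). Set beside the earlier pair, the same kind of change looks alike on the two cores, even though its place on the ring is not the same in the two pairs: the same change on two cores in this assay, a number 2 percentage points lower (within the scatter) from compound 2 to compound 1 and a number 1 percentage points lower (within the scatter) from compound 3 to compound 4, 1 percentage points apart, within the scatter of two such steps. This shows that, in these two pairs, swapping one of these halogens for the other leaves the growth-inhibition reading unmoved at the single concentration tested, but it does not show that a change with a step beyond the scatter would carry from one core to the other, and two pairs that both stay within the scatter make no general rule for the series.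

The compounds shown carry only fluoro or chloro on the aromatic ring, and they leave open whether a bromo, a methoxy group or an amine at the same place would move the number on either core. Also open is which of the features separating the two cores goes with the higher numbers of compound 3 and compound 4, as no pair shown differs in only one of those features.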